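From fluoro to chloro on compound 3

The compounds below may be only part of what the source reports. "The series", "measured", "known", "first", "only" and "open" are said of these compounds alone.

compound 1 `Cc1c(OCCCCOc2ccc(C(=O)O)cc2Cl)ccc(C(=O)CC2CCCC2)c1O` gives 120%
compound 2 `COc1cc(C(=O)O)ccc1OCCCCOc1ccc(C(=O)CC(C)C)c(O)c1C` gives 99%
compound 3 `Cc1c(OCCCCOc2ccc(C(=O)O)cc2F)ccc(C(=O)CC(C)C)c1O` gives 106%
compound 4 `Cc1c(OCCCCOc2ccc(C(=O)O)cc2Cl)ccc(C(=O)CC(C)C)c1O` has not yet been measured

These numbers come from an ADME assay on a cell-free system (plasma, Rattus norvegicus) for metabolic stability, read by LC-MS, with a stated time of 60 min, tested at 100 uM; on this read-out lower numbers stand for a less stable compound and higher numbers for a more stable compound. Compound 3 holds the second highest of the three numbers at 106%. It cannot be told apart from compound 2 at 99%. The gap between compound 3 and compound 1 lies beyond the scatter. Compound 1 gives 120%.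

Compound 4 differs from compound 3 in one place: chloro in place of fluoro on an aromatic carbon. This puts chloro in place of fluoro on an aromatic carbon, ortho to a large group and meta to a carboxy group, so 4-carboxy-2-fluorophenyl becomes 4-carboxy-2-chlorophenyl.

Within the data shown here, the one measured step at this place is a number 7 percentage points higher from compound 2 to compound 3 (within the scatter), with fluoro in place of methoxy, and it stays within the scatter. Compound 1 already carries the 4-carboxy-2-chlorophenyl and reads 120%, but it also differs from compound 4 elsewhere, so its number does not isolate the chloro. No shift beyond the scatter is therefore expected in this assay.

The expected change is a number 2 percentage points higher from compound 3 to compound 4 (within the scatter), which is no larger than the scatter. For compound 4 the estimated value is 108%, with an expected range from 95% to 120%.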

Compound 4, percent of the compound remaining: 123%
The estimate for compound 4 lay 15 percentage points below the measured number; measured number outside the range, above it.
By their numbers in this assay, from the lowest: compounds 2 and 3 (each within the scatter of the next); then compounds 1 and 4 (each within the scatter of the next).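

In this assay, chloro in place of fluoro on this aromatic carbon, ortho to a large group and meta to a carboxy group, gives a number 17 percentage points higher from compound 3 to compound 4 (beyond the scatter) and chloro in place of methoxy gives a number 24 percentage points higher from compound 2 to compound 4 (beyond the scatter), so this position does respond to the group it carries, which the one earlier step here, a number 7 percentage points higher from compound 2 to compound 3 (within the scatter), had not shown. With the 4-carboxy-2-chlorophenyl held constant, isopropyl in place of cyclopentyl gives a number 3 percentage points higher from compound 1 to compound 4 (within the scatter), which shows that compound 1 and compound 4 cannot be told apart and that the higher reading of compound 1 relative to compound 3 need not depend on its cyclopentyl. Nothing available offers an explanation for the separation of chloro from fluoro and methoxy at this position.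

From the compounds shown here alone, whether bromo or a nitrile on this carbon would read with chloro or with fluoro and methoxy remains open. Also open, going by these compounds, is whether the chloro step would hold with an amide in place of the carboxy group, or with fluoro alongside the cyclopentyl of compound 1.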